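The source may report more compounds than this note shows. Statements on the series, on what has been measured and on what is new or still open speak of the compounds shown alone.

Measured in a functional assay on HCT-15 cells (Homo sapiens) for cytotoxicity, read by CCK-8 assay and cell counting, with a stated time of 72 h; a higher number here means a weaker inhibitor, a lower number a stronger inhibitor:

compound 1 `COc1cc(OC)cc(-c2cc3ccccc3c(-c3cccc(O)c3)n2)c1` gives 840 nM
compound 2 `COc1ccc(-c2cc3cc(C)ccc3c(-c3cccc(O)c3)n2)cc1OC` gives 370 nM

Compound 2 stands at the lowest of the two numbers in this assay; its nearest neighbour is compound 1, whose value lies higher by a gap that is beyond the usual scatter. Among the measured compounds shown here, no single-point step between measured compounds exists in this pair, so the two values are noted only as they stand.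

The next compound, compound 3 `COc1cccc(-c2nc(-c3ccc(OC)c(OC)c3)cc3cc(C)ccc23)c1`, differs from compound 2 by methyl in place of hydrogen on an oxygen on an aromatic ring, turning the hydroxy into methoxy and the 3-hydroxyphenyl into a 3-methoxyphenyl. For the measured compounds named here, nothing among the measured compounds shows the effect of capping this oxygen, so the direction is open. A modest rise in the number is expected for compound 3, in the form of a step of a 1.9-fold higher number from compound 2 to compound 3 (0.28 log units; within the scatter), though a result within the scatter would not be surprising. The estimate for compound 3 in this assay is therefore 700 nM, with a range from 200 nM to 2500 nM.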

Compound 3, half-maximal inhibitory concentration: 1840 nM
Compound 3: the middle estimate sits 2.6-fold (0.42 log units) below what was measured; the range from low to high includes it.
By their numbers in this assay, from the lowest: compound 2; then compound 1; then compound 3.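

In this assay, among the compounds shown here, replacing the hydrogen on this oxygen with methyl, which turns the 3-hydroxyphenyl into a 3-methoxyphenyl, gives a 5.0-fold higher number from compound 2 to compound 3 (0.70 log units; beyond the scatter) and provides the first single-change reading. At this position, the hydroxy form therefore gives the lower number, and capping the oxygen with this one carbon weakens the compound in this read-out rather than leaving it unchanged. Nothing available explains the rise, so the observation remains a single paired result, tied to the substituted core shared by compound 2 and compound 3.

The pair cannot separate loss of the hydrogen on the oxygen from the presence of the entering methyl, a question that an amine or a fluorine at the same place, or a longer chain such as ethoxy on the oxygen, could help to address. It also leaves open whether the same cap would raise the number on the core of compound 1, which differs from compound 2 in more than one place and so gives no reading of this change.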